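Removing a methyl from the sulfonyl ring

The source may hold more compounds than are shown below. What is called first, only, known or untested is meant among the compounds shown, and "the series" means these compounds.

Measured so far:
Compound 1 `CC(=O)c1ccc(NC(=O)C(CC(C)C)N(C(=O)c2ccccc2)S(=O)(=O)c2ccc(C)cc2)cc1`: 63.1%
Compound 2 `CC(=O)c1ccc(NC(=O)C(C(C)C)N(C(=O)c2ccccc2)S(=O)(=O)c2ccc(C)cc2)cc1`: 29.7%

For the measured compounds named here, in a functional assay for inhibition, read by spectrophotometry, with a stated time of 20 min, tested at 3 mg/mL (on this read-out lower numbers stand for a weaker effect and higher numbers for a stronger effect at the one concentration tested), compound 1 gives 63.1% and stands highest of the two numbers measured, with compound 2 as its nearest neighbour; the only step recorded is a number 33.4 percentage points lower from compound 1 to compound 2 (beyond the scatter), and it concerns the isobutyl-bearing chain carbon, not the sulfonyl ring.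

Compound 3 `CC(=O)c1ccc(NC(=O)C(CC(C)C)N(C(=O)c2ccccc2)S(=O)(=O)c2ccccc2)cc1` has not been measured. It differs from compound 1 by hydrogen in place of methyl on an aromatic carbon, that is, (4-methylphenyl)sulfonyl to phenylsulfonyl. Going by the values given here, no measured step touches this part of the shared core, so there is nothing here that points to a change of any size or direction; the one known step lies elsewhere and cannot be carried over.

Compound 3 is therefore expected to come out near compound 1, with a step of a number 5.1 percentage points lower from compound 1 to compound 3 (within the scatter) that stays within the scatter, and its estimated value is 58%, within a range from 42% to 74%.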

Compound 3, a percentage reported as inhibition, at one concentration (the size of the read-out at that concentration, not a potency): 40.7%
For compound 3 the middle estimate is 17.3 percentage points above the measured one, and the stated range ends above it.
By their numbers in this assay, from the lowest: compound 2; then compound 3; then compound 1.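

In this assay, hydrogen in place of methyl on an aromatic carbon gives a number 22.4 percentage points lower from compound 1 to compound 3 (beyond the scatter), so the sulfonyl ring is not a silent part of the molecule. Even one methyl on this ring, a single carbon in the 4-methylphenyl group, makes a difference beyond the scatter. Together with the earlier step, this gives two separate places on compound 1 where a change lowers the number, though nothing available explains why removing this methyl has this effect.

From the compounds shown here alone, it remains open whether an ethyl group, a methoxy group or a chlorine atom in the same place would keep, lower or raise the number. Also unknown is whether removing this methyl from compound 2, which carries isopropyl instead of isobutyl, would produce a similar step.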